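The compounds below may be only part of what the source reports. "The series", "measured", "known", "first", "only" and "open" are said of these compounds alone.

Working notes on the series in a functional assay on MDA-MB-231 cells (Homo sapiens) for inhibition, read by sulforhodamine B assay, with a stated time of 48 h, tested at 10 uM; on this read-out higher numbers stand for more inhibition at the one concentration tested (going by the name of the read-out) and lower numbers for less inhibition.

Three compounds on a shared core carry different aryl groups at one position. Compound 1 `COc1ccc(-c2cn3ccnc3c(-c3ccc4ncn(C5CCCCC5)c4c3)n2)cc1` gives 71.1% in this assay. Compound 2 `Brc1ccc(-c2cn3ccnc3c(-c3ccc4ncn(C5CCCCC5)c4c3)n2)cc1` gives 22.8%. Compound 3 `c1csc(-c2cn3ccnc3c(-c3ccc4ncn(C5CCCCC5)c4c3)n2)c1` gives 10.8%, the lowest of the three numbers; its nearest neighbour is compound 2, its most distant is compound 1, both steps lying beyond the scatter.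

The next compound, compound 4 `FC(F)(F)c1cccc(-c2cn3ccnc3c(-c3ccc4ncn(C5CCCCC5)c4c3)n2)c1`, has not yet been measured in this assay. The change from compound 3 is 3-(trifluoromethyl)phenyl in place of thiophen-2-yl on an aromatic carbon.

Among the measured compounds shown here, two measured steps bear on it, both in the opposite direction: a number 60.3 percentage points lower from compound 1 to compound 3 (beyond the scatter) and a number 12 percentage points lower from compound 2 to compound 3 (beyond the scatter). Each exchanged a six-membered aryl group for thiophen-2-yl and each lowered the number, one by a large amount and one modestly. Going back from thiophen-2-yl to a six-membered aryl is therefore expected to raise the number, but the two earlier aryl groups differ so widely between themselves that the size of the rise is uncertain; nothing in the series carries a trifluoromethyl group.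

Compound 4 is thus expected to read about 35%, within a range of 10% to 70%, meaning an expected step of a number 24.2 percentage points higher from compound 3 to compound 4 (beyond the scatter).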

Compound 4, a percentage reported as inhibition, at one concentration (the size of the read-out at that concentration, not a potency) in the MDA-MB-231 assay: 21.8%
Compound 4: the middle estimate sits 13.2 percentage points above what was measured, and the stated range covers the measured number.
By their numbers in the MDA-MB-231 assay, from the lowest: compound 3; then compounds 4 and 2 (each within the scatter of the next); then compound 1.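

In the MDA-MB-231 assay, a return from thiophen-2-yl to a six-membered aryl group brings only part of what the earlier steps suggested, a number 11 percentage points higher from compound 3 to compound 4 (beyond the scatter), so a six-membered aryl group at this position does not by itself give a high number. 3-(Trifluoromethyl)phenyl and 4-bromophenyl cannot be told apart here, a number 1 percentage points lower from compound 2 to compound 4 (within the scatter), while 4-methoxyphenyl stands well clear, a number 49.3 percentage points lower from compound 1 to compound 4 (beyond the scatter); among the compounds shown, the high number therefore belongs to compound 1 alone rather than to the six-membered aryl groups as a class. In a physicochemical assay for lipophilicity, using the shake flask method, in phosphate buffer, measured as octanol-water partition, with a stated time of 85 min, at pH 7.4 (a lower number here means a more polar compound, a higher number a more lipophilic compound), compound 3 gives 1.38 and compound 4 gives 1.72. The modest step between compound 3 and compound 4 also comes with a shift in the physicochemical assay, although a single pair cannot show that the two are linked: the measured partition coefficient of compound 3, 1.38, and of compound 4, 1.72, a number 0.34 log units higher (beyond the scatter)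

Still open, as far as these compounds go, is whether the number of compound 1 follows from the methoxy group itself or from its place on the ring, a question that a 3-methoxyphenyl or a 4-ethoxyphenyl group at this position would help to separate. The compounds shown also leave open whether the physicochemical assay tracks the numbers in the MDA-MB-231 assay across the wider series, including compound 1.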